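Swapping a Hydroxycyclopropyl Amide for a Chloropyrazole Amide

The source may report more compounds than this note shows. Statements on the series, on what has been measured and on what is new or still open speak of the compounds shown alone.

Compound 1 `CC1(C)Cc2c(sc(NC(=O)C3CNC(=O)C3)c2C(N)=O)C(C)(C)O1` gives > 10000 nM in an assay on cells for positive allosteric modulation of Cystic fibrosis transmembrane conductance regulator variant F508del (Homo sapiens), with stated times of 10 min and 7 s, in the presence of a further agent that is not named here; on this read-out lower numbers stand for an effect already at smaller amounts and higher numbers for an effect only at larger amounts of compound; this is a limit of the assay, not a number.
Compound 2 `CC1(C)Cc2c(sc(NC(=O)C3(O)CC3)c2C(N)=O)C(C)(C)O1` gives 23 nM in this assay.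

Within the data shown here, compound 2 holds the only actual number on this read-out; the one other value shown is a limit (the limit of > 10000 nM in this assay, at which 1 of the 2 values shown sits). Among the measured compounds shown here, the single measured step, an at least 430-fold lower number from compound 1 to compound 2 (2.63 log units; beyond the scatter), exchanges 5-oxopyrrolidin-3-yl for 1-hydroxycyclopropyl on the carbonyl carbon and is large.

Compound 3 `CC1(C)Cc2c(sc(NC(=O)c3[nH]ncc3Cl)c2C(N)=O)C(C)(C)O1` differs from compound 2 by a group of 6 heavy atoms (3 carbon, 2 nitrogen, 1 chlorine; one five-membered aromatic ring with 2 hetero atoms) in place of a group of 4 heavy atoms (3 carbon, 1 oxygen; one three-membered non-aromatic ring of carbon only), on a carbonyl carbon.

For the measured compounds named here, the measured step concerns the same carbonyl carbon but a different pair of groups, so it shows only that changes at this place can move the number a great deal, not which way this particular change goes. With no closer guide, the expected step of a 1.3-fold higher number from compound 2 to compound 3 (0.12 log units; within the scatter) is small and within the scatter. Compound 3 is estimated at 30 nM, with a range from 5 nM to 300 nM.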

Compound 3, half-maximal effective concentration: 2 nM
Compound 3: the middle estimate sits 15-fold (1.18 log units) above what was measured; the whole stated range lies above it.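

Placed on the same carbonyl carbon, a chlorine-bearing five-membered aromatic ring takes the number in this assay lower than the 1-hydroxycyclopropyl group does, with a 12-fold lower number from compound 2 to compound 3 (1.06 log units; beyond the scatter), so the small saturated ring of compound 2 is not the best group seen at this place. Both groups carry the same counts of hydrogen-bond donors and acceptors, so those counts alone do not separate them, and the wider comparison, an at least 5000-fold lower number from compound 1 to compound 3 (3.69 log units; beyond the scatter), shows how much the choice of group on this carbonyl carbon can matter while the shared core stays unchanged. The value of compound 1 is a limit and not a number, and the size of that wider step rests on it: the limit of > 10000 nM in this assay, at which 1 of the 3 values shown sits.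

The compounds shown do not tell whether the gain comes from the chlorine or from the aromatic ring itself, which a plain pyrazole, or one with methyl or bromine in place of chlorine, would help to separate. They also leave open how far the ring's nitrogen-bound hydrogen counts, as a pyrazole with a methyl group on that nitrogen would show, and they give no reason for the lower number.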